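The compounds below may be only part of what the source reports. "The series", "measured", "known", "first", "only" and "open" are said of these compounds alone.

Measured compounds:
- Compound 1 `COc1cc(N/C=C\C(=O)c2cn(-c3ccccc3)nc2-c2ccc(Cl)cc2)cc(OC)c1OC`: 12700 nM
- Compound 2 `COc1ccc(-c2nn(-c3ccccc3)cc2C(=O)/C=C\Nc2ccc(Cl)cc2)cc1`: 4760 nM
- Compound 3 `COc1ccc(-c2nn(-c3ccccc3)cc2C(=O)/C=C\Nc2ccc(C(F)(F)F)cc2)cc1`: 9870 nM

These three compounds were tested in a functional assay on HT-29 cells (Homo sapiens) for antiproliferative activity, read by MTT assay, with a stated time of 48 h; a higher number here means a weaker inhibitor, a lower number a stronger inhibitor. Compound 3 gives 9870 nM, a number close to that of compound 1, which gives 12700 nM; the two cannot be told apart. Within the data shown here, compound 2, with 4760 nM, stands clearly apart from compound 3, and the only single-point step among the measured compounds is a 2.1-fold higher number from compound 2 to compound 3 (0.32 log units; beyond the scatter).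

Compound 4 `COc1ccc(-c2nn(-c3ccccc3)cc2C(=O)/C=C\Nc2cc(OC)c(OC)c(OC)c2)cc1` has not yet been measured in this assay. Compared with compound 3, the change is 3,4,5-trimethoxyphenyl in place of 4-(trifluoromethyl)phenyl on an amine nitrogen. Among the measured compounds shown here, no measured step covers exactly this exchange. For the measured compounds named here, the only guide is compound 1, which carries the same 3,4,5-trimethoxyphenyl on the amine nitrogen but a different group on the shared core, and which gives 12700 nM, a number not distinguishable from compound 3. The step of a 2.1-fold higher number from compound 2 to compound 3 (0.32 log units; beyond the scatter) shows that changes at this position can move the number, but by a modest amount. On that basis compound 4 is expected to stay near compound 3, with an estimated step of a 1.1-fold higher number from compound 3 to compound 4 (0.05 log units; within the scatter). The estimate for compound 4 is 11000 nM, with a range from 4000 nM to 30000 nM.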

Compound 4, half-maximal inhibitory concentration: 14600 nM
Compound 4: middle estimate off by 1.3-fold (0.12 log units), on the low side, and the stated range covers the measured number.
By their numbers in this assay, from the lowest: compound 2; then compounds 3, 1 and 4 (each within the scatter of the next).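

In this assay there is a 1.5-fold higher number from compound 3 to compound 4 (0.17 log units; within the scatter) so 3,4,5-trimethoxyphenyl and 4-(trifluoromethyl)phenyl on the amine nitrogen cannot be told apart, although only the first carries hydrogen-bond acceptors. Against 4-chlorophenyl, the same group gives a 3.1-fold higher number from compound 2 to compound 4 (0.49 log units; beyond the scatter) so 4-chlorophenyl alone stands apart among the three groups at this place, though only modestly. The exchange of methoxy for chloro on an aromatic carbon, with 3,4,5-trimethoxyphenyl on the amine nitrogen, gives a 1.1-fold higher number from compound 1 to compound 4 (0.06 log units; within the scatter) and so shows no readable effect. Nothing measured here explains these differences. From the compounds shown here alone, every group on this nitrogen is a substituted phenyl ring, so the effect of a plain alkyl chain in its place, or of an amine or a carboxylic acid on the ring, remains open. Also open, going by these compounds, is whether 4-chlorophenyl on the amine nitrogen would keep its lower number on the core of compound 1.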